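Piperazine in place of acrylamide on the shared core

The source may hold more compounds than are shown below. What is called first, only, known or untested is meant among the compounds shown, and "the series" means these compounds.

Measured in a functional assay on BaF3 cells (Mus musculus) for inhibition, read by CCK-8 assay, with a stated time of 72 h; a higher number here means a weaker inhibitor of growth, a lower number a stronger inhibitor of growth:
compound 1, `Cc1ccc(NC(=O)Nc2ccc(Oc3cc(/N=C/N(C)C)ncn3)cc2)cc1C(F)(F)F`: 6610 nM
compound 2, `C=CC(=O)Nc1cc(Oc2ccc(NC(=O)Nc3ccc(C)c(C(F)(F)F)c3)cc2)ncn1`: 1940 nM
compound 3, `CC(=O)Nc1cc(Oc2ccc(NC(=O)Nc3ccc(C)c(C(F)(F)F)c3)cc2)ncn1`: 3230 nM

Compound 2 holds the lowest of the three numbers. Its nearest neighbour is a 1.7-fold higher number from compound 2 to compound 3 (0.22 log units; within the scatter), a gap within the scatter, so no order is claimed there. Its furthest is a 3.4-fold lower number from compound 1 to compound 2 (0.53 log units; beyond the scatter), which lies beyond the scatter.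

Compound 4, `Cc1ccc(NC(=O)Nc2ccc(Oc3cc(N4CCN[C@H](C)C4)ncn3)cc2)cc1C(F)(F)F`, carries 3-methylpiperazin-1-yl in place of (vinylcarbonyl)amino on an aromatic carbon. The three measured steps all alter the group on this same aromatic carbon: a 3.4-fold lower number from compound 1 to compound 2 (0.53 log units; beyond the scatter), a 2.0-fold lower number from compound 1 to compound 3 (0.31 log units; beyond the scatter) and a 1.7-fold higher number from compound 2 to compound 3 (0.22 log units; within the scatter). None of them brings in a ring or a group of this size, so they bound the coming step only loosely; what they do show is that changes at this carbon have so far stayed modest. A modest step is therefore expected, more probably toward a higher number, since compound 2 already sits at the lowest value seen. Compound 4 is expected to give 4500 nM, within 1500 nM to 14000 nM. This estimate corresponds to an expected 2.3-fold higher number from compound 2 to compound 4 (0.37 log units; beyond the scatter).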

Compound 4, concentration for 50% growth inhibition: 8920 nM
Compound 4: middle estimate off by 2.0-fold (0.30 log units), on the low side; the range from low to high includes it.
By their numbers in this assay, from the lowest: compounds 2 and 3 (each within the scatter of the next); then compounds 1 and 4 (each within the scatter of the next).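

In this assay, 3-methylpiperazin-1-yl brings a six-membered non-aromatic ring onto this aromatic carbon, and the number rises from both acylated amino compounds (a 4.6-fold higher number from compound 2 to compound 4 (0.66 log units; beyond the scatter); a 2.8-fold higher number from compound 3 to compound 4 (0.44 log units; beyond the scatter)). Against the group on compound 1, the change stays within the scatter (a 1.3-fold higher number from compound 1 to compound 4 (0.13 log units; within the scatter)), so the four compounds fall into two tiers, with compounds 2 and 3, which carry a carbonyl group here, below compounds 1 and 4, which do not, and no compound goes against this split. The data give no measured basis for explaining this split.

Still open, from the compounds shown here alone, is whether the ring itself or its methyl and defined stereocentre set the level of compound 4, which piperazine without the methyl or the opposite enantiomer would address. Morpholine or a simple dimethylamino group at this carbon would test whether the split holds beyond these four compounds.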